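Second bromine on the shared core: an expectation

The compounds below may be only part of what the source reports. "The series", "measured", "known", "first", "only" and "open" are said of these compounds alone.

Measured compounds:
- Compound 1 `CCC(=O)N1N=C(C)CC1c1cc(Br)ccc1O`: 37800 nM
- Compound 2 `CC1=NN(S(=O)(=O)c2ccc(C)cc2)C(c2cc(Br)ccc2O)C1`: 33200 nM

In a functional assay on PC-3 cells (Homo sapiens) for cytotoxicity, read by MTT assay, with a stated time of 48 h (on this read-out lower numbers stand for stronger inhibition and higher numbers for weaker inhibition), compound 2 gives 33200 nM, the lowest of the two numbers shown. Compound 1 gives 37800 nM in this assay, which lies within the scatter of the number for compound 2, so the two compounds cannot be told apart here.

Compound 3 `CC1=NN(S(=O)(=O)c2ccc(C)cc2)C(c2cc(Br)cc(Br)c2O)C1` is not yet measured in this assay. It differs from compound 2 by one change: bromo in place of hydrogen on an aromatic carbon. Among the compounds with values here, no measured pair shows this kind of change, so no size of step is known from the data. The step from compound 2 to compound 3 is expected to be small, a 1.3-fold lower number from compound 2 to compound 3 (0.11 log units; within the scatter), not clearly beyond the scatter in either direction. Compound 3 is therefore estimated at 26000 nM, within a range from 8000 nM to 80000 nM.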

Compound 3, half-maximal inhibitory concentration: 51200 nM
The estimate for compound 3 lay 2.0-fold (0.29 log units) below the measured number; measured number inside the range.
By their numbers in this assay, from the lowest: compounds 2, 1 and 3 (each within the scatter of the next).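

In this assay, adding a bromo group ortho to a hydroxy group gives a small step (a 1.5-fold higher number from compound 2 to compound 3 (0.19 log units; within the scatter)). Within the data shown here, this is the first reading of this change, and it shows that the position accepts a bromine with no difference that can be separated from the scatter. Nothing available explains this result. On these data alone, whether an amine or a carboxylic acid at this same position would give a step beyond the scatter remains open. So does whether the same bromo change would behave alike on compound 1.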